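Halogen swap on the benzylic aryl: cytotoxicity outlook for compound 4

A few compounds are considered here, and "the series" means these few. Any claim that something is new, unique, unknown or untested is made for them only; others in the source may bear on it.

Compound 2 `N/C(=N/NC(CC(=O)c1ccc(-n2ccnc2)cc1)c1cccc(Cl)c1)c1ccccn1` gives 68600 nM in an ADME assay on Vero cells (Chlorocebus sabaeus) for cytotoxicity, read by MTT assay, with a stated time of 72 h (on this read-out lower numbers stand for higher toxicity in this test and higher numbers for lower toxicity in this test), the highest of the three numbers in hand. Compound 3 `N/C(=N/NC(CC(=O)c1ccc(-n2ccnc2)cc1)c1ccccc1)c1ccccn1` gives 63500 nM in this assay; the step of a 1.1-fold lower number from compound 2 to compound 3 (0.03 log units; within the scatter) stays within the scatter, so no order between these two can be claimed. Compound 1 `N/C(=N/NC(CC(=O)c1ccc(-n2ccnc2)cc1)c1cccc(F)c1)c1ccccn1` gives 26500 nM in this assay and is the one clearly set apart: the step of a 2.6-fold higher number from compound 1 to compound 2 (0.41 log units; beyond the scatter) and the step of a 2.4-fold higher number from compound 1 to compound 3 (0.38 log units; beyond the scatter) are both beyond the scatter and modest in size.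

The next compound, compound 4 `N/C(=N/NC(CC(=O)c1ccc(-n2ccnc2)cc1)c1ccccc1F)c1ccccn1`, differs from compound 2 by 2-fluorophenyl in place of 3-chlorophenyl on a saturated chain carbon bound to an amine nitrogen and a saturated chain carbon. Among the compounds with values here, two measured steps bear on it. The step from compound 1 to compound 2 shows that exchanging fluoro for chloro on the aromatic carbon moved the number by a modest amount, and the step from compound 1 to compound 3 shows a similar move when fluoro is replaced by hydrogen. Both point to a fluoro-bearing phenyl giving a lower number than the 3-chlorophenyl. Within the data shown here, the fluoro of compound 4, however, sits on the 2-fluorophenyl, a group no measured compound carries, so the direction is expected but the size is uncertain. A modest lowering toward the number of compound 1 is therefore expected.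

Compound 4 is expected at 38000 nM in this assay, with a range of 17000 nM to 85000 nM. This corresponds to an expected step of a 1.8-fold lower number from compound 2 to compound 4 (0.26 log units; within the scatter) in this assay.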

Compound 4, half-maximal cytotoxic concentration: 62100 nM
Compound 4: middle estimate off by 1.6-fold (0.21 log units), on the low side; measured number inside the range.
By their numbers in this assay, from the lowest: compound 1; then compounds 4, 3 and 2 (each within the scatter of the next).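

In this assay a fluoro on the aromatic ring does not by itself go with a lower number: the step of a 1.0-fold lower number from compound 3 to compound 4 (0.01 log units; within the scatter) and the step of a 1.1-fold lower number from compound 2 to compound 4 (0.04 log units; within the scatter) both stay within the scatter, so at this saturated chain carbon the 2-fluorophenyl cannot be told apart from the phenyl of compound 3 or the 3-chlorophenyl of compound 2. The step of a 2.3-fold higher number from compound 1 to compound 4 (0.37 log units; beyond the scatter) is beyond the scatter and modest, so the two fluorophenyl groups do not read alike, and compound 1 with its 3-fluorophenyl stands alone against compounds 2, 3 and 4, which lie within the scatter of one another. Nothing on hand gives a reason for this separation.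

Still open, from the compounds shown here alone, is whether the lower number of compound 1 is particular to the 3-fluorophenyl or would also appear with another group on the ring, such as a methoxy, an amine or a carboxylic acid. Going by these compounds, the shared core is the same in all four compounds, so it also remains open whether these halogen exchanges would read the same way on a different core.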